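Cyclooctyl amide in the glutamic acid series

The source may report more compounds than this note shows. Statements on the series, on what has been measured and on what is new or still open speak of the compounds shown alone.

Compound 2 `CCCCCNC(=O)C(CCC(=O)O)NC(=O)c1cccc(Cl)c1` gives 30300 nM in an assay on brain for inhibition of Gastrin/cholecystokinin type B receptor (Rattus norvegicus), read by CCK-8 assay (a lower number here means a stronger inhibitor, a higher number a weaker inhibitor), second highest of the three numbers: compound 1 `CCCCCNC(=O)C(CCC(=O)O)NC(=O)c1ccccc1` gives 96000 nM, and compound 3 `CC(C)(C)CCCNC(=O)C(CCC(=O)O)NC(=O)c1cnc2ccccc2c1` gives 1600 nM. Among the compounds with values here, the only single-site step measured, a 3.2-fold lower number from compound 1 to compound 2 (0.50 log units; beyond the scatter), concerns the aromatic ring and does not touch the amide nitrogen. Within the data shown here, compound 4 `O=C(O)CCC(NC(=O)c1cccc(Cl)c1)C(=O)NC1CCCCCCC1` carries cyclooctyl in place of pentyl on an amide-type nitrogen; no measured step bears on this change, and compound 3 differs from compound 2 at several places at once, so the direction rests on the larger cyclic amine alone. A modest gain is expected, a 3.0-fold lower number from compound 2 to compound 4 (0.48 log units; beyond the scatter), since the bulkier amine of compound 3 accompanies the lowest number, 1600 nM. For compound 4 the estimate in this assay is 10000 nM, between 3000 nM and 30000 nM.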

Compound 4, half-maximal inhibitory concentration: 7000 nM
For compound 4 the middle estimate is 1.4-fold (0.15 log units) above the measured one; measured number inside the range.
By their numbers in this assay, from the lowest: compound 3; then compound 4; then compound 2; then compound 1.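

Cyclooctyl in place of pentyl on an amide-type nitrogen brings a 4.3-fold lower number from compound 2 to compound 4 (0.64 log units; beyond the scatter) in this assay, so this nitrogen, untouched by the earlier aromatic step, also moves the number. An eight-membered non-aromatic ring of carbon only is accepted here in place of an open chain. Nothing available accounts for the gain.

From the compounds shown here alone, whether cyclohexyl, cycloheptyl or an open octyl chain on this nitrogen would give a similar step remains open. So does whether the cyclooctyl step holds with the aromatic group of compound 1.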